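This account rests on a few compounds, and the source may have more. Where it says the series, first, only, none or still open, it means among the compounds named here.

Compound 1 (`CC1CCN(C2CCN(S(=O)(=O)c3cccc(-c4ccccc4C(F)(F)F)c3)CC2)CC1`) and compound 2 (`Cc1cc(C)cc(-c2cccc(S(=O)(=O)N3CCC(N4CCC(C)CC4)CC3)c2)c1`) share a core and differ in one group. Both were tested in an ADME assay on HCT-116 cells (Homo sapiens) for cytotoxicity, read by CellTiter-Glo, with a stated time of 72 h; on this read-out higher numbers stand for weaker inhibition and lower numbers for stronger inhibition. In this test, compound 1 gives > 5000 nM, which is a limit of the assay and not a number. Compound 2 gives > 5000 nM, which is also a limit. Compound 2 therefore has no exact position, and the evidence so far is the limit of > 5000 nM in this assay, at which 2 of the 2 values shown sit. Going by the values given here, the only measured change is a step that the two limits leave unreadable from compound 1 to compound 2, so there is no measured size to carry forward.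

Compound 3 (`Cc1ccc(-c2cccc(S(=O)(=O)N3CCC(N4CCC(C)CC4)CC3)c2)cc1`) has not yet been measured. It differs from compound 2 in one place: 4-methylphenyl in place of 3,5-dimethylphenyl on an aromatic carbon. Here, 4-methylphenyl stands in place of 3,5-dimethylphenyl on an aromatic carbon, meta to a large group.

With no readable step as a guide, the expectation rests on the limit shared by the two measured compounds. In this assay, no change beyond the scatter is expected, and no direction can be assigned. The expected step is a step that the limit leaves unreadable from compound 2 to compound 3. For compound 3 the estimate is 7000 nM, with an expected range from 3000 nM to 15000 nM.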

Compound 3, half-maximal inhibitory concentration: > 5000 nM
Compound 3 gave a limit, no number; the forecaster's own chance of this, stated with the estimate: 85%; the middle value is on the limit's open side.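

Compound 3 also gives a limit and not a number, so the steps linking compound 1, compound 2 and compound 3 cannot be read. The evidence stays a single limit: the limit of > 5000 nM in this assay, at which 3 of the 3 values shown sit. The compounds shown leave open how strongly each one inhibits in this assay, and whether changing the group on the aromatic carbon alters that read-out at all.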